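The source may report more compounds than this note shows. Statements on the series, on what has been measured and on what is new or still open speak of the compounds shown alone.

Measured so far in an ADME assay on microsomes from liver (Homo sapiens) for metabolic stability; a lower number here means slower removal, a higher number faster removal of the compound:
Compound 1 `CC(C)n1cc(-c2ccnc3[nH]c(C4CCNCC4)cc23)ccc1=O` gives < 3 uL/min, which is a limit of the assay, not a number.
Compound 2 `CNC(=O)CN1CCC(c2cc3c(-c4ccc(=O)n(C(C)C)c4)ccnc3[nH]2)CC1` gives 8.6 uL/min.
Compound 3 `CC(C)n1cc(-c2ccnc3[nH]c(C4CCN(CC(=O)N5CCCC5)CC4)cc23)ccc1=O` gives 45 uL/min.

Compound 3 stands highest of the two numbers in hand; the nearest is compound 2, with a 5.2-fold higher number from compound 2 to compound 3 (0.72 log units; beyond the scatter). Compound 1 sits at the limit of < 3 uL/min in this assay, at which 1 of the 3 values shown sits. Compound 4 `CC(C)n1cc(-c2ccnc3[nH]c(C4CCN(CC(=O)N5CCCCC5)CC4)cc23)ccc1=O` differs from compound 3 at one place only: piperidin-1-yl in place of pyrrolidin-1-yl on a carbonyl carbon. Going by the values given here, no measured step matches this exchange directly. The step that bears on it is the one at the same carbonyl carbon, a 5.2-fold higher number from compound 2 to compound 3 (0.72 log units; beyond the scatter), where pyrrolidin-1-yl in place of methylamino raised the number; an at least 2.8-fold higher number from compound 1 to compound 2 (0.45 log units; beyond the scatter) and an at least 15-fold higher number from compound 1 to compound 3 (1.17 log units; beyond the scatter) also run upward. The change here is smaller than that one, so a step upward near the edge of the scatter is expected. Compound 4 is estimated at 70 uL/min (range 30 uL/min to 160 uL/min), an expected step of a 1.6-fold higher number from compound 3 to compound 4 (0.19 log units; within the scatter).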

Compound 4, intrinsic clearance in a liver preparation (reported as CLH), per the amount of preparation that the assay uses: > 300 uL/min
Compound 4: no number, only a limit (the forecaster's own chance of this, stated with the estimate: 5%); at least 4.2-fold (0.63 log units) between middle value and limit.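

In this assay compound 4 gives a limit, not a number: the limit of > 300 uL/min in this assay, at which 1 of the 4 values shown sits.
At this carbonyl carbon, the exchange of a five-membered for a six-membered ring alone gives an at least 6.6-fold higher number from compound 3 to compound 4 (0.82 log units; beyond the scatter) and so is not a minor change. Against methylamino, piperidin-1-yl gives an at least 34-fold higher number from compound 2 to compound 4 (1.54 log units; beyond the scatter) on the same carbon. The full ((piperidin-1-yl)carbonyl)methyl on the ring amine nitrogen gives an at least 100-fold higher number from compound 1 to compound 4 (2.00 log units; beyond the scatter) and sets the widest step in the series.
Open, from the compounds shown here alone, is where morpholin-4-yl or dimethylamino on this carbonyl carbon would fall among compound 2, compound 3 and compound 4. Going by these compounds, the actual number for compound 4 also remains open.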